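The compounds below may be only part of what the source reports. "The series", "measured", "known", "first", "only" and "open" are said of these compounds alone.

In a functional assay on MCF7 cells (Homo sapiens) for antiproliferative activity, read by MTT assay, with a stated time of 48 h (a lower number here means a stronger inhibitor, a higher number a weaker inhibitor), the measured compounds are
Compound 1 `N=C(N)N/N=C(/C=C/c1ccc(Br)cc1)c1ccccc1` with 250 nM
Compound 2 `N=C(N)N/N=C(/C=C/c1ccccc1Cl)c1ccccc1` with 4200 nM

Compound 2 holds the higher of the two numbers. Compound 3 `N=C(N)N/N=C(/C=C/c1ccccc1Br)c1ccccc1` differs from it by one swap (bromo in place of chloro on an aromatic carbon), bromo in place of chloro on an aromatic carbon, ortho to a large group. Among the measured compounds shown here, only one measured step bears on this (a 17-fold higher number from compound 1 to compound 2 (1.23 log units; beyond the scatter)). It is large, but it changed the halogen and its place together, so it cannot separate the two. Starting from compound 2 at 4200 nM and with the place unchanged, no step beyond the scatter is expected in this assay (a 1.4-fold lower number from compound 2 to compound 3 (0.15 log units; within the scatter)). Compound 3 is estimated at 3000 nM (expected range 900 nM to 8000 nM).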

Compound 3, half-maximal inhibitory concentration: 4200 nM
The estimate for compound 3 lay 1.4-fold (0.15 log units) below the measured number; low and high end bracket the measured number.
By their numbers in this assay, from the lowest: compound 1; then compounds 2 and 3 (each within the scatter of the next).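

In this assay, changing the halogen while keeping its place gives no change at the digits printed from compound 2 to compound 3 (within the scatter), so chloro and bromo cannot be told apart at this position, ortho to a large group. Keeping bromo and changing only its place, with 2-bromophenyl in place of 4-bromophenyl, gives a 17-fold higher number from compound 1 to compound 3 (1.23 log units; beyond the scatter), so this large step goes with the place and not with the halogen. Nothing measured here explains why the place matters.

As far as these compounds go, whether an amine or a methoxy group at this position would match the two halogens stays open, as does whether 4-chlorophenyl would match the 4-bromophenyl of compound 1.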